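A few compounds are considered here, and "the series" means these few. Any claim that something is new, unique, unknown or untested is made for them only; others in the source may bear on it.

In an ADME assay on TERT-RPE1 cells (Homo sapiens) for cytotoxicity, read by MTT assay, with a stated time of 72 h (on this read-out higher numbers stand for weaker inhibition and lower numbers for stronger inhibition), compound 1 (`COc1ccc(/C=C2/CN(C)/C(=N/c3ccc(C(C)(C)C)cc3)S2)cc1`) gives 23500 nM as its value. Compound 3 (`FC(F)(F)c1cc(/N=C2/NC/C(=C/c3ccccc3)S2)cc(C(F)(F)F)c1`) gives 32800 nM as its value, and the two numbers lie within the usual scatter of repeated measurements, so compound 1 shares its place on the scale with compound 3. Compound 2 (`C=C1CN(C)/C(=N/c2ccccc2)S1`) reads > 100000 nM in this assay and that reading is a limit of the assay.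

The next compound to be tested, compound 4 (`COc1ccc(/C=C2/CN(C)/C(=N/c3ccc(Br)cc3)S2)cc1`), keeps the core of compound 1 and alters a single group: bromo in place of tert-butyl on an aromatic carbon with bromo in place of tert-butyl on an aromatic carbon, para to a large group. Among the measured compounds shown here, no two measured compounds differ in just one place, so the data give no direct guide to this swap. Compound 3 at 32800 nM carries quite different groups on its aromatic ring yet stays within the scatter of compound 1, which suggests a modest expectation. No step beyond the scatter is expected in this assay and any drift should lean slightly toward a higher number, meaning weaker inhibition. The expected change is a 1.3-fold higher number from compound 1 to compound 4 (0.11 log units; within the scatter) and its uncertainty is wide. For compound 4 the estimated value is 30000 nM with an expected range from 12000 nM to 75000 nM as its limits.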

Compound 4, half-maximal inhibitory concentration: 61300 nM
Beside the measured number, compound 4's estimate is 2.0-fold (0.31 log units) below it; low and high end bracket the measured number.
By their numbers in this assay, from the lowest: compounds 1, 3 and 4 (each within the scatter of the next, the first and the last beyond it). At a limit, above all of these: compound 2.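

Replacing tert-butyl with bromo on an aromatic carbon, para to a large group, gives a 2.6-fold higher number from compound 1 to compound 4 (0.42 log units; beyond the scatter) in this assay. This is the only pair shown that differs in one place, and its step lies beyond the scatter, so a change at this position can register in this cell read-out, with the higher number standing for weaker inhibition. Compound 4 also gives a real number rather than a limit, so this modest step can be read in full, though the assay does have an upper end: the limit of > 100000 nM in this assay, at which 1 of the 4 values shown sits.

A single pair cannot show which difference between tert-butyl, with 4 heavy atoms, and bromo, with 1, matters here, so the compounds shown leave open how the read-out would respond to other groups at this place, such as a chloro, an amine or a carboxylic acid. They also leave open whether the same swap would give a similar step on a different framework, such as that of compound 3, which carries neither of these two groups.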